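The source may hold more compounds than are shown below. What is called first, only, known or untested is meant among the compounds shown, and "the series" means these compounds.

Working notes on the series, solubility read-out.

Compound 1 `NC(=O)C1CCN(c2nc(-c3cccnc3)nc3c2CN(Cc2ccccc2)CC3)CC1` gives in a physicochemical assay for solubility, read by HPLC, with a stated time of 24 h, at pH 7.4, tested at 250 uM (on this read-out higher numbers stand for higher solubility and lower numbers for lower solubility), a value of 224000 nM. Compound 2 `CN(C)CCN1CCN(c2nc(-c3cccnc3)nc3c2CN(Cc2ccccc2)CC3)CC1` gives in this assay a value of 247000 nM. Compound 3 `COc1ccc(CN2CCc3nc(-c4ccccn4)nc(N4CCN(CCN(C)C)CC4)c3C2)cc1` gives in this assay a value of 229000 nM. The difference between the core of compound 3 and the core of compound 2 is not broken down here. All three values lie within the usual scatter of one another, so no order among them is claimed. Compound 4 `COc1ccc(CN2CCc3nc(-c4ccccn4)nc(N4CCC(C(N)=O)CC4)c3C2)cc1` has not yet been measured in this assay.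

The change from compound 2 to compound 1 is 4-carbamoylpiperidin-1-yl in place of 4-(2-(dimethylamino)ethyl)piperazin-1-yl on an aromatic carbon, and it gave a 1.1-fold lower number from compound 2 to compound 1 (0.04 log units; within the scatter). The change from compound 3 to compound 4 is 4-carbamoylpiperidin-1-yl in place of 4-(2-(dimethylamino)ethyl)piperazin-1-yl on an aromatic carbon. This is the same kind of change, not the same: around the place, the carbon in compound 4 is meta to a pyridin-2-yl group rather than meta to a pyridin-3-yl group. The earlier instance stayed within the scatter, as a 1.1-fold lower number from compound 2 to compound 1 (0.04 log units; within the scatter) shows. On that basis the step expected from compound 3 to compound 4 is a 1.1-fold lower number from compound 3 to compound 4 (0.04 log units; within the scatter). Compound 4 is therefore estimated at 210000 nM, with an expected range from 120000 nM to 380000 nM.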

Compound 4, solubility: 224000 nM
Estimate against measurement, compound 4: 1.1-fold (0.03 log units) below; measured number inside the range.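

In this assay, putting 4-carbamoylpiperidin-1-yl in place of 4-(2-(dimethylamino)ethyl)piperazin-1-yl stays within the scatter on both cores: a 1.1-fold lower number from compound 2 to compound 1 (0.04 log units; within the scatter), and a 1.0-fold lower number from compound 3 to compound 4 (0.01 log units; within the scatter). The change therefore carries from one core to the other in these two pairs as a step too small to read, but two pairs set no rule for the series, and with all four values close to the tested concentration, the read-out may leave little room to separate the compounds. Nothing given here bears on why the step is this small.

Left open is whether the step stays within the scatter when a carboxylic acid or a primary amine stands in place of the carbamoyl group of 4-carbamoylpiperidin-1-yl. Also open, on these data alone, is whether a longer chain in place of the 2-(dimethylamino)ethyl chain would give a step that can be read on either core.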